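Trading allyloxy for methyl on a carbonyl carbon

The compounds below may be only part of what the source reports. "The series", "measured", "known", "first", "only" and "open" are said of these compounds alone.

Within the data shown here, in a functional assay on ASPC1 cells (Homo sapiens) for inhibition, read by MTT assay, with a stated time of 96 h (a lower number here means a stronger inhibitor of growth, a higher number a weaker inhibitor of growth), compound 1 `C=CCOC(=O)SCCCCCCNC(=O)c1cc(-c2ccncc2)n[nH]1` gives 27500 nM, the only exact number available so far. Compound 2 `CCCCCCCC/C=C\CCCCCCCC(=O)SCCCCCCNC(=O)c1cc(-c2ccncc2)n[nH]1` gives > 50000 nM, which is a limit of the assay and not a number. Compound 3 `CC(=O)SCCCCCCNC(=O)c1cc(-c2ccncc2)n[nH]1` keeps the rest of compound 1 but carries methyl in place of allyloxy on a carbonyl carbon. Among the measured compounds shown here, no measured pair yet shows what this change does, so any forecast is loose. For the measured compounds named here, the one hint is that compound 2, with a larger group on that carbonyl carbon, reached only > 50000 nM. A smaller group might therefore give stronger growth inhibition in this assay, though this rests on very little. The expected step of a 2.3-fold lower number from compound 1 to compound 3 (0.36 log units; beyond the scatter) is a moderate one in that direction. For compound 3 the estimated value is 12000 nM, with an expected range of 3000 nM to 45000 nM.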

Compound 3, concentration for 50% growth inhibition: > 50000 nM
Compound 3: a limit, no number (the forecaster's own chance of this, stated with the estimate: 12%); at least 4.1-fold (0.61 log units) between middle value and limit.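

In this assay compound 3 gives > 50000 nM, which is a limit of the assay and not a number. Read as a step, this is an at least 1.8-fold higher number from compound 1 to compound 3 (0.25 log units; that floor lies within the scatter), so methyl on this carbonyl carbon brings no sign of stronger growth inhibition, while the size of any loss stays unknown. The small methyl group of compound 3 and the much larger group of compound 2 now end at the same limit, which leaves allyloxy as the only group here with an exact value: the limit of > 50000 nM in this assay, at which 2 of the 3 values shown sit.

The compounds shown leave open whether the oxygen or the allyl part of allyloxy matters more at this position, a question that methoxy or a plain propyl group there could help to separate. They also leave open whether any group on this carbonyl carbon, such as benzyloxy or an amine, could give stronger growth inhibition than compound 1.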